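A Saturated Ring in Place of an Aromatic One

The compounds below may be only part of what the source reports. "The series", "measured", "known", "first", "only" and "open" are said of these compounds alone.

Measured so far:
compound 1, `CCCCc1cnc(Cc2ccc(-c3ccccc3C(=O)O)cc2)[nH]1`: > 10000 nM
compound 2, `Cc1cccc(Cc2cnc(CCc3ccc(-c4ccccc4C(=O)O)cc3)[nH]2)c1`: 75 nM
compound 3, `CCCCc1cnc(C(CCCO)Cc2ccc(-c3ccccc3C(=O)O)cc2)[nH]1`: 238 nM

Of the compounds shown here, three sharing one core have been tested in an in vitro functional assay on cells for agonist activity at Bombesin receptor subtype-3 (Mus musculus), read by luminescence and calcium flux; on this read-out higher numbers stand for an effect only at larger amounts of compound and lower numbers for an effect already at smaller amounts. Compound 1 gives only a limit of the assay, > 10000 nM, and no number. Compound 2 gives 75 nM, the lowest of the two numbers at hand. Compound 3 gives 238 nM, and the gap between compound 2 and compound 3 lies beyond the usual scatter. No two of these compounds differ in a single place, so no measured step can be read from them.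

Compound 4, `O=C(O)c1ccccc1-c1ccc(CCc2ncc(CC3CCCCCC3)[nH]2)cc1`, has not yet been measured. Set against compound 2, it carries cycloheptyl in place of 3-methylphenyl on a saturated chain carbon bound to an aromatic carbon. For the measured compounds named here, nothing among the measured compounds isolates this change, so the direction of the step rests on expectation alone. The author expects a small loss, with the step of a 2.0-fold higher number from compound 2 to compound 4 (0.30 log units; within the scatter) lying near the edge of the scatter. Compound 4 is therefore estimated to give 150 nM, with a range from 30 nM to 800 nM.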

Compound 4, half-maximal effective concentration: 5.7 nM
The estimate for compound 4 lay 26-fold (1.42 log units) above the measured number, and the stated range ends above it.
By their numbers in this assay, from the lowest: compound 4; then compound 2; then compound 3. At a limit, above all of these: compound 1.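

In this assay, the result shows that this place, on a saturated chain carbon bound to an aromatic carbon, does not need an aromatic ring: cycloheptyl in place of 3-methylphenyl gives a 13-fold lower number from compound 2 to compound 4 (1.12 log units; beyond the scatter), a large step. The two groups have the same count of heavy atoms and neither has a hydrogen-bond donor or acceptor, so the step accompanies a change from a six-membered aromatic ring to a seven-membered non-aromatic ring. Nothing measured here gives a reason for the step.

Ring size and saturation change together in this step, so the compounds shown cannot separate them, and a cyclohexyl group at the same place would be needed to do so. They also leave open how an open heptyl chain or a ring carrying an amine would fare there.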